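A Bromine on the Anilino Ring of Compound 3

The source may hold more compounds than are shown below. What is called first, only, known or untested is meant among the compounds shown, and "the series" means these compounds.

Compound 3, `CC1(C)O[C@H]2O[C@H](Cn3cc(CN4C(=O)/C(=N\Nc5ccccc5)c5ccccc54)nn3)[C@H](O)[C@H]2O1`, was tested in an ADME assay on Vero cells (Chlorocebus sabaeus) for cytotoxicity, read by fluorescence and resazurin assay, with a stated time of 3 days (a lower number here means that less compound is tolerated, a higher number that more compound is tolerated), where compound 3 gives 82100 nM. Among the three compounds with numbers so far, compound 3 stands second highest. Its nearest neighbour is compound 1, `CC(=O)C[C@H]1O[C@@H](On2cc(CN3C(=O)/C(=N\Nc4ccc(C#N)cc4)c4ccccc43)nn2)[C@H](OC(C)=O)[C@@H](OC(C)=O)[C@@H]1OC(C)=O`, which in this assay gives 75400 nM; the furthest is compound 2, `CC(=O)C[C@H]1O[C@@H](On2cc(CN3C(=O)/C(=N\Nc4cccc(Cl)c4)c4ccccc43)nn2)[C@H](OC(C)=O)[C@@H](OC(C)=O)[C@@H]1OC(C)=O`, which in this assay gives 117000 nM. All three lie within the usual scatter of one another, so none of them can be told apart on these numbers.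

Compound 4, `CC1(C)O[C@H]2O[C@H](Cn3cc(CN4C(=O)/C(=N\Nc5ccc(Br)cc5)c5ccccc54)nn3)[C@H](O)[C@H]2O1`, differs from compound 3 in one place: bromo in place of hydrogen on an aromatic carbon.

Going by the values given here, only one measured step bears on this change. From compound 1 to compound 2 the group on the amine nitrogen was exchanged, 3-chlorophenyl in place of 4-cyanophenyl, and the result was a 1.6-fold higher number from compound 1 to compound 2 (0.19 log units; within the scatter). That is a change on the same ring that would carry the new bromo group, and it did not move the number beyond the scatter. Nothing here suggests that a bromo group on that ring would behave differently. For compound 4 in this assay the expected step is therefore a 1.0-fold higher number from compound 3 to compound 4 (0.02 log units; within the scatter), a change no larger than the scatter. The estimate for compound 4 is 85000 nM, expected to fall between 40000 nM and 180000 nM.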

Compound 4, half-maximal cytotoxic concentration: 72900 nM
For compound 4 the middle estimate is 1.2-fold (0.07 log units) above the measured one; the range from low to high includes it.
By their numbers in this assay, from the lowest: compounds 4, 1, 3 and 2 (each within the scatter of the next).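

In this assay, going from phenyl to 4-bromophenyl gives a 1.1-fold lower number from compound 3 to compound 4 (0.05 log units; within the scatter), so compound 3 and compound 4 cannot be told apart on this read-out. The earlier step compared one substituted ring with another, on a different core, whereas this one compares an unsubstituted ring with a substituted one while the rest of the molecule stays the same. It shows that, on the core of compound 3, adding one bromine atom to an aromatic carbon, para to a large group, leaves the number within the scatter, although a single pair of compounds says nothing about other substituents or other cores. Nothing in the available data explains this result.

The compounds shown leave open whether a quite different group at this same place, such as an amine, a carboxylic acid or a longer chain, would also stay within the scatter. They also leave open whether bromo on another carbon of this ring, or on the core of compound 1, would give a similar step.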